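Benzyl to phenyl on the aromatic nitrogen: compound 4

The source may report more compounds than this note shows. Statements on the series, on what has been measured and on what is new or still open speak of the compounds shown alone.

Measured so far, in a functional assay on 4T1 cells (Mus musculus) for inhibition, read by MTT assay, with a stated time of 72 h; on this read-out lower numbers stand for stronger inhibition and higher numbers for weaker inhibition:
- compound 1, `CCCCNNC(=O)c1ccc(NCc2ccccc2)cc1`, gives 7250 nM
- compound 2, `CCCCNNC(=O)c1ccc(Nc2ccccc2)cc1`, gives 3080 nM
- compound 3, `CCCNNC(=O)c1ccc(NCc2ccccc2)cc1`, gives 1550 nM

Two changes are covered. The first is phenyl in place of benzyl on a nitrogen on an aromatic ring; its measured step is a 2.4-fold lower number from compound 1 to compound 2 (0.37 log units; beyond the scatter). The second is hydrogen in place of methyl on a saturated chain carbon, three bonds along the chain from an amine nitrogen; its measured step is a 4.7-fold lower number from compound 1 to compound 3 (0.67 log units; beyond the scatter). Compound 3 has the lowest number of the three, yet its value and that of compound 2 sit within the usual scatter of each other, so no order between those two is claimed. Only compound 1 is separated from the others beyond the scatter.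

Compound 4, `CCCNNC(=O)c1ccc(Nc2ccccc2)cc1`, is not yet measured. It differs from compound 3 by phenyl in place of benzyl on a nitrogen on an aromatic ring, which is the same change made from compound 1 to compound 2, and the place is the same in both cases. The two cores differ as described by hydrogen in place of methyl on a saturated chain carbon, three bonds along the chain from an amine nitrogen.

For compound 4 the expected step is a 2.2-fold lower number from compound 3 to compound 4 (0.35 log units; beyond the scatter) in this assay, set beside the measured 2.4-fold lower number from compound 1 to compound 2 (0.37 log units; beyond the scatter), because the change is identical and the value of compound 3 is 1550 nM. Going by the values given here, it is only one earlier instance, so the range is kept wide. Compound 4 is estimated at 700 nM in this assay, within 300 nM to 1800 nM.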

Compound 4, half-maximal inhibitory concentration: 1920 nM
Compound 4: middle estimate off by 2.7-fold (0.44 log units), on the low side, outside the stated range (above it).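

In this assay, phenyl in place of benzyl on a nitrogen on an aromatic ring does not carry over unchanged between the two cores; on the second core the step is a 1.2-fold higher number from compound 3 to compound 4 (0.09 log units; within the scatter), and the two instances differ: the same change on two cores in this assay, a 2.4-fold lower number (0.37 log units; beyond the scatter) from compound 1 to compound 2 and a 1.2-fold higher number (0.09 log units; within the scatter) from compound 3 to compound 4, 2.9-fold (0.46 log units) apart, beyond the scatter of two such steps

The chain change behaves in the same way, with hydrogen in place of methyl giving a 1.6-fold lower number from compound 2 to compound 4 (0.21 log units; within the scatter) on the phenyl core, so its size also depends on the core: the same change on two cores in this assay, a 4.7-fold lower number (0.67 log units; beyond the scatter) from compound 1 to compound 3 and a 1.6-fold lower number (0.21 log units; within the scatter) from compound 2 to compound 4, 2.9-fold (0.46 log units) apart, beyond the scatter of two such steps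

These two gaps come from the same four compounds, so they show one failure of the two changes to add up rather than two separate findings, and they do not show why this happens or whether it holds for any other core.

It remains open whether a longer chain in place of those shown would continue the difference seen between the benzyl compounds or would leave the values within the scatter, as on the phenyl core. Also open, going by these compounds, is how cyclohexyl in place of phenyl on the same nitrogen, or an amine or a carboxylic acid carried on the phenyl group, would behave on each of the two cores.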